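A few compounds are considered here, and "the series" means these few. Any claim that something is new, unique, unknown or untested is made for them only; others in the source may bear on it.

Three compounds have the same atoms and bonds and differ only in configuration as drawn: compound 1 `C=C(C)[C@@H]1CC[C@](C)(O)[C@H]1/C=C/C(C)=C/[C@@H]1C[C@@]2([C@H](OC)O1)[C@H](CCCO)/C(=C(\C)C=O)CC[C@]2(C)O`, compound 2 `C=C(C)[C@H]1CC[C@@](C)(O)[C@@H]1/C=C/C(C)=C/[C@@H]1C[C@@]2([C@H](OC)O1)[C@H](CCCO)/C(=C(/C)C=O)CC[C@]2(C)O` and compound 3 `C=C(C)[C@H]1CC[C@@](C)(O)[C@@H]1/C=C/C(C)=C/[C@@H]1C[C@@]2([C@H](OC)O1)[C@H](CCCO)/C(=C(\C)C=O)CC[C@]2(C)O`. All three were tested in a functional assay on MCF7 cells (Homo sapiens) for cytotoxicity, read by MTT assay, with a stated time of 72 h; on this read-out higher numbers stand for weaker inhibition and lower numbers for stronger inhibition. Compound 1 gives > 10000 nM, which is a limit of the assay and not a number. Compound 2 gives > 10000 nM, also a limit. Compound 3 gives > 10000 nM, again a limit, so it stands level with the other two on the numbers shown and has no exact value of its own.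

Compound 4 `C=C(C)[C@H]1CC[C@@](C)(O)[C@@H]1/C=C/C(C)=C/[C@@H]1C[C@@]2([C@H](OCC)O1)[C@H](CCCO)/C(=C(\C)C=O)CC[C@]2(C)O` keeps the configuration of compound 3 and changes one group: methyl in place of hydrogen on a saturated chain carbon bound to an oxygen on a saturated carbon, that is, methoxy to ethoxy. The measured steps are changes of configuration only: a step that the two limits leave unreadable from compound 1 to compound 2, a step that the two limits leave unreadable from compound 1 to compound 3 and a step that the two limits leave unreadable from compound 2 to compound 3. From the compounds shown here alone, their sizes stay unknown because of the limit of > 10000 nM in this assay, at which 3 of the 3 values shown sit. None of them tests a change of this kind, so the expectation rests only on compound 3 and its > 10000 nM, a limit.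

The expected change is a step that the limit leaves unreadable from compound 3 to compound 4, an estimate of no shift beyond the usual scatter in this assay, in either direction. For compound 4 the estimated value is 12000 nM, with an expected range of 4000 nM to 30000 nM.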

Compound 4, half-maximal inhibitory concentration: > 10000 nM
Compound 4: a limit, no number; the forecaster's own chance of this, stated with the estimate: 75%; the middle value lies beyond the limit too.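

For the compounds shown here, no step from compound 3 to compound 4 can be read in this assay, as each of the two compounds gives a limit and not a number: the limit of > 10000 nM in this assay, at which 4 of the 4 values shown sit.

The compounds shown leave open whether methoxy to ethoxy, or any difference in configuration among compound 1, compound 2 and compound 3, changes cytotoxicity at all.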